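Compound 3 to compound 4: a pyrazole isomer swap

This account rests on a few compounds, and the source may have more. Where it says the series, first, only, none or still open, it means among the compounds named here.

In a toxicity assay on L02 cells (Homo sapiens) for cytotoxicity, read by MTT assay, with a stated time of 72 h (a lower number here means a stronger inhibitor, a higher number a weaker inhibitor), compound 1 `C=CC(=O)N1CCC(Oc2nc(Nc3ccc(N(C)CCN(C)C)cc3OC)nc3[nH]ccc23)CC1` gives 19000 nM and compound 2 `C=CC(=O)N1CCC(Oc2nc(Nc3ccc(N4CCN(C)CC4)cc3OC)nc3ccsc23)CC1` gives 1970 nM while compound 3 `C=CC(=O)N1CCC(Oc2nc(Nc3cnn(C)c3)nc3ccsc23)CC1` gives 8920 nM as the second highest of the three numbers, beyond the scatter from both others. Compound 4 `C=CC(=O)N1CCC(Oc2nc(Nc3ccn(C)n3)nc3ccsc23)CC1` carries the change 1-methyl-1H-pyrazol-3-yl in place of 1-methyl-1H-pyrazol-4-yl on a nitrogen on an aromatic ring with 1-methyl-1H-pyrazol-3-yl in place of 1-methyl-1H-pyrazol-4-yl on a nitrogen on an aromatic ring. Among the measured compounds shown here, no measured pair shows this change, so the expectation rests on compound 3 at 8920 nM as the starting value. The expected step of a 1.1-fold higher number from compound 3 to compound 4 (0.05 log units; within the scatter) stays within the scatter, with no firm direction. For compound 4 the estimated value is 10000 nM with 4000 nM to 25000 nM as the expected range.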

Compound 4, half-maximal inhibitory concentration: 16700 nM
Compound 4: middle estimate off by 1.7-fold (0.22 log units), on the low side; the measured number falls inside the stated range.
By their numbers in this assay, from the lowest: compound 2; then compounds 3, 4 and 1 (each within the scatter of the next, the first and the last beyond it).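

In this assay, among the compounds shown here, the exchange of 1-methyl-1H-pyrazol-4-yl for 1-methyl-1H-pyrazol-3-yl gives a 1.9-fold higher number from compound 3 to compound 4 (0.27 log units; within the scatter), the first comparison of compounds that differ in one place. On this nitrogen on an aromatic ring, the two pyrazole isomers are therefore not distinguished by this assay. No supporting measurement bears on the origin of this step. Still open, on these data alone, is whether a pyridine in place of the pyrazole, or an ethyl group in place of its methyl, would give a step beyond the scatter.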